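The source may report more compounds than this note shows. Statements on the series, on what has been measured and on what is new or still open speak of the compounds shown alone.

Among the compounds with values here, compound 1 `CCc1cc(/C=C/C(=O)c2ccccc2NC(=O)NS(=O)(=O)c2ccc(C)cc2)cc(OC)c1OC` gives 19.2 ug/mL in an ADME assay on the whole organism for cytotoxicity, with Artemia salina as the target, with a stated time of 24 h (a lower number here means that less compound is needed, a higher number that more compound is needed for the effect), the highest of the two numbers so far, while compound 2 `Cc1ccc(S(=O)(=O)NC(=O)Nc2ccccc2C(=O)/C=C/c2ccc(F)cc2)cc1` gives 3.96 ug/mL. Within the data shown here, the one measured step, a 4.8-fold lower number from compound 1 to compound 2 (0.69 log units; beyond the scatter), bears directly on the change to compound 3 `Cc1ccc(S(=O)(=O)NC(=O)Nc2ccccc2C(=O)/C=C/c2cccc(Br)c2)cc1`, where (3-bromophenyl in place of 3-ethyl-4,5-dimethoxyphenyl on a double-bonded chain carbon bound to a double-bonded chain carbon). The same aryl group leaves in both steps, and the group that enters is again a halophenyl. For compound 3 a step of similar direction and modest size is therefore expected, a 3.8-fold lower number from compound 1 to compound 3 (0.58 log units; beyond the scatter). Compound 3 is estimated at 5 ug/mL, with a range from 2 ug/mL to 13 ug/mL.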

Compound 3, concentration for half-maximal effect: 4.02 ug/mL
Estimate against measurement, compound 3: 1.2-fold (0.09 log units) above; low and high end bracket the measured number.
By their numbers in this assay, from the lowest: compounds 2 and 3 (each within the scatter of the next); then compound 1.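

In this assay, the lower number seen with 4-fluorophenyl recurs with a second halophenyl at this place, 3-bromophenyl, with a 4.8-fold lower number from compound 1 to compound 3 (0.68 log units; beyond the scatter). Between the two halophenyl groups the result is a 1.0-fold higher number from compound 2 to compound 3 (0.01 log units; within the scatter), so compound 2 and compound 3 cannot be told apart here, despite a different halogen at a different ring position.

From the compounds shown here alone, whether the lower number needs a halogen at all, or would also hold with unsubstituted phenyl or an aminophenyl, stays open. No measurement at hand accounts for either step.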